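Benzylamino to methylpiperazinyl on the shared core

A few compounds are considered here, and "the series" means these few. Any claim that something is new, unique, unknown or untested is made for them only; others in the source may bear on it.

The series shares a core bearing a chloro group, read in a functional assay on HCT-116 cells (Homo sapiens) for antiproliferative activity, read by CCK-8 assay, with a stated time of 72 h, tested at 8 uM; a lower number here means a weaker effect, a higher number a stronger effect of the compound at the concentration tested. Compound 1 `Nc1ccccc1NC(=O)c1ccc(Cn2cnc3c(NCc4ccccc4)nc(Cl)nc32)cc1` gives 78.4% in this assay. Compound 2 `Nc1ccccc1NC(=O)c1ccc(Cn2cnc3c(Nc4ccc(-c5ccccn5)cc4)nc(Cl)nc32)cc1` gives 73.7% in this assay, and compound 3 `CCCCn1cnc2c(Nc3ccccc3)nc(NCOCc3ccc(C(=O)Nc4ccccc4N)cc3)nc21` gives 74.9% in this assay. Within the data shown here, compound 1 sits at the upper edge of the three numbers, yet its gaps to compound 3 and to compound 2 are both within the scatter, so no compound separates from it.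

Among the measured compounds shown here, the one measured step is a number 4.7 percentage points lower from compound 1 to compound 2 (within the scatter), a change of the group on the nitrogen while the nitrogen itself is kept; it moved nothing beyond the scatter.

Compound 4 `CN1CCN(c2nc(Cl)nc3c2ncn3Cc2ccc(C(=O)Nc3ccccc3N)cc2)CC1` differs from compound 1 as follows: 4-methylpiperazin-1-yl in place of benzylamino on an aromatic carbon. The hydrogen-bond donor of compound 1 is lost along with the aromatic ring, and a non-aromatic ring enters at the same aromatic carbon. For the measured compounds named here, the step from compound 1 to compound 2 bears on this only in that exchanging the group at this carbon cost little; no measured step removes the donor. The expectation is therefore a step of a number 8.4 percentage points lower from compound 1 to compound 4 (within the scatter), modest and downward if anything, carrying a wide range.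

Compound 4 is estimated at 70%, between 52% and 84%.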

Compound 4, a percentage reported as inhibition, at one concentration (the size of the read-out at that concentration, not a potency): 72.8%
Compound 4: the middle estimate sits 2.8 percentage points below what was measured, within the range that was stated.
By their numbers in this assay, from the lowest: compounds 4, 2, 3 and 1 (each within the scatter of the next).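

In this assay, the exchange of benzylamino for 4-methylpiperazin-1-yl gives a number 5.6 percentage points lower from compound 1 to compound 4 (within the scatter). Unlike the earlier step, which kept the nitrogen and its hydrogen, this change removes the hydrogen-bond donor and the carbon-only aromatic ring at this aromatic carbon and places a non-aromatic ring with 2 hetero atoms there, so at the one concentration tested neither feature of benzylamino is shown to be required for the read-out. No measurement at hand bears on why the read-out holds across this change.

The read-out is a size at one concentration, not a potency, so a difference in potency between these compounds could lie hidden within the scatter. Open questions are whether a morpholine ring, a dimethylamino group or a piperazine carrying a carboxylic acid on a longer chain at this same carbon would stay level with these compounds, and whether the chloro group, present in all of the compounds compared here, can give way to an amine without a step beyond the scatter.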